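Methyl additions on a shared core at the adenosine A3 receptor

A few compounds are considered here, and "the series" means these few. Any claim that something is new, unique, unknown or untested is made for them only; others in the source may bear on it.

Compound 1 `CCCOC(=O)C1=C(C)NC(=O)NC1c1ccoc1` gives 11% in an assay on membranes from HeLa cells for displacement of a labelled ligand from adenosine receptor A3 (Homo sapiens), read by scintillation counting, with a stated time of 180 min, tested at 1 uM; a higher number here means more inhibition at the concentration tested (going by the name of the read-out), a lower number less inhibition. Compound 2 `CC1=C(C(=O)OCC(C)C)C(c2ccoc2)NC(=O)N1` differs from compound 1 by methyl in place of hydrogen on a saturated chain carbon bound to two saturated chain carbons, a change that produced a number 5 percentage points higher from compound 1 to compound 2 (within the scatter), and compound 2 gives 16%. Compound 3 `CCCOC(=O)C1=C(C)N(C)C(=O)NC1c1ccoc1` carries instead (methyl in place of hydrogen on an amide-type nitrogen in a ring), which produced a number 5 percentage points higher from compound 1 to compound 3 (within the scatter), and compound 3 gives 16%. Compound 4 `CC1=C(C(=O)OCC(C)C)C(c2ccoc2)NC(=O)N1C` has not been measured. It differs from compound 3 by methyl in place of hydrogen on a saturated chain carbon bound to two saturated chain carbons, the same change that separates compound 1 from compound 2, made here on a core that differs by methyl in place of hydrogen on an amide-type nitrogen in a ring. Since that change gave only a small step between compound 1 and compound 2, a step of a number 4 percentage points higher from compound 3 to compound 4 (within the scatter) is expected for compound 4 in this assay. Compound 4 is therefore estimated at 20%, most likely between 8% and 32%.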

Compound 4, a percentage reported as inhibition, at one concentration (the size of the read-out at that concentration, not a potency): 16%
Compound 4: middle estimate off by 4 percentage points, on the high side, within the range that was stated.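

In this assay, the propoxy to isobutoxy change gives no change at the digits printed from compound 3 to compound 4 (within the scatter), and methyl in place of hydrogen on the amide-type nitrogen in the ring gives no change at the digits printed from compound 2 to compound 4 (within the scatter). The propoxy to isobutoxy change cannot be told apart between the two cores, but this does not prove that it carries over, since each step lies within the scatter and a real effect this small would not show: the same change on two cores in this assay, a number 5 percentage points higher (within the scatter) from compound 1 to compound 2 and no change at the digits printed (within the scatter) from compound 3 to compound 4, 5 percentage points apart, within the scatter of two such steps. The same holds for the methyl on the nitrogen: the same change on two cores in this assay, a number 5 percentage points higher (within the scatter) from compound 1 to compound 3 and no change at the digits printed (within the scatter) from compound 2 to compound 4, 5 percentage points apart, within the scatter of two such steps.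

The compounds shown cover only methyl additions. They leave open whether a longer chain in place of isobutoxy, or a chain ending in an amine or a carboxylic acid, would give a step beyond the scatter, and whether such a step would carry from one core to the other.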